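The source may hold more compounds than are shown below. What is called first, only, known or untested is meant among the compounds shown, and "the series" means these compounds.

Measured so far:
- compound 1, `O=C(Nc1cccc(F)c1)c1ccc2cccc(O)c2n1`: 2.5
- compound 2, `O=C(Nc1ccccc1Cl)c1ccc2cccc(O)c2n1`: 2.5
- compound 3, `O=C(Nc1ccccc1Br)c1ccc2cccc(O)c2n1`: 2.5

All three share one core and differ only in the ring attached to the amide nitrogen. In a physicochemical assay for lipophilicity, read by HPLC (on this read-out higher numbers stand for higher lipophilicity and lower numbers for lower lipophilicity), compound 1 gives 2.5, and compounds 2 and 3 sit level with it: the step of no change at the digits printed from compound 1 to compound 2 (within the scatter) and the step of no change at the digits printed from compound 1 to compound 3 (within the scatter) both stay within the scatter, as does the step of no change at the digits printed from compound 2 to compound 3 (within the scatter). Compound 1 therefore stands neither high nor low among the measured compounds; the three values cannot be told apart.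

Compound 4, `O=C(Nc1cccc([N+](=O)[O-])c1)c1ccc2cccc(O)c2n1`, is not yet measured. It follows from compound 1 by the change (nitro in place of fluoro on an aromatic carbon). Among the compounds with values here, none of the measured steps covers a nitro group; they only show that swapping one halogen for another, or moving it around the ring, left this assay unchanged. The change to compound 4 is of a different kind, so those steps give no firm guide, and the expectation rests on the change itself. A small drop is expected, of the size a number 0.40 log units lower from compound 1 to compound 4 (beyond the scatter), though a result within the scatter would not surprise.

Compound 4 is thus estimated at 2.1, with a range from 1.7 to 2.5.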

Compound 4, partition coefficient: 2.5
For compound 4 the middle estimate is 0.40 log units below the measured one, and the stated range covers the measured number.
By their numbers in this assay, from the lowest: compounds 1, 2, 3 and 4 (each within the scatter of the next).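

Within the data shown here, until now the only changes on the ring attached to the amide nitrogen were exchanges of one halogen for another, together with a shift of where that halogen sits, so the flat numbers could have been a feature of halogens alone. Compound 4 tests something of a different kind, a nitro group built of nitrogen and oxygen in place of fluoro, on an aromatic carbon meta to a large group, and in this assay this swap gives no change at the digits printed from compound 1 to compound 4 (within the scatter), so among these four compounds the flat reading is no longer confined to halogens. No supporting information is available to say why the read-out holds steady across this swap.

What the compounds shown leave open is whether a group of another type on this ring, such as an amine, a carboxylic acid or a longer alkyl chain, would finally move the number beyond the scatter. All four compounds also keep the shared core unchanged, so they cannot tell whether a change there would leave this assay just as steady.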